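Adding a methoxy group to a chlorophenyl-bearing thione

The source may report more compounds than this note shows. Statements on the series, on what has been measured and on what is new or still open speak of the compounds shown alone.

Two compounds sharing one core were tested in a functional assay on MCF7 cells (Homo sapiens) for inhibition, read by sulforhodamine B assay, with a stated time of 24 h; on this read-out higher numbers stand for weaker inhibition of growth and lower numbers for stronger inhibition of growth. Compound 1 `COc1ccc(NC(=O)C2=C(C)NC(=S)NC2c2cn(-c3ccccc3)nc2-c2ccccc2)cc1` carries a methoxy on its anilide ring and an unsubstituted phenyl on the pyrazole; in this assay compound 1 gives 77300 nM. Compound 2 `CC1=C(C(=O)Nc2ccccc2)C(c2cn(-c3ccccc3)nc2-c2ccc(Cl)cc2)NC(=S)N1` instead has a plain anilide and a chlorine on the pyrazole phenyl; in this assay compound 2 gives 61500 nM, a number that sits within the scatter of the value of compound 1, so the two cannot be separated. Compound 3 `COc1ccc(NC(=O)C2=C(C)NC(=S)NC2c2cn(-c3ccccc3)nc2-c2ccc(Cl)cc2)cc1` combines both features. It differs from compound 2 by methoxy in place of hydrogen on an aromatic carbon. For the measured compounds named here, with no measured step available for this change, and the two numbers so close, the step from compound 2 to compound 3 is expected to be small, a 1.0-fold higher number from compound 2 to compound 3 (0.00 log units; within the scatter), in no firm direction. Compound 3 is therefore estimated at 62000 nM, within a range from 25000 nM to 150000 nM.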

Compound 3, concentration for 50% growth inhibition: 70000 nM
For compound 3 the middle estimate is 1.1-fold (0.05 log units) below the measured one; the measured number falls inside the stated range.
By their numbers in this assay, from the lowest: compounds 2, 3 and 1 (each within the scatter of the next).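

In this assay, methoxy in place of hydrogen on an aromatic carbon, para to a large group, gives a 1.1-fold higher number from compound 2 to compound 3 (0.06 log units; within the scatter) and so leaves compound 2 and compound 3 inseparable, now read directly on a matched pair with the chlorine present. For the compounds shown here, the chloro group on the other phenyl ring, read for the first time as a single change, gives a 1.1-fold lower number from compound 1 to compound 3 (0.04 log units; within the scatter) and likewise separates nothing. No measurement is at hand that would account for these numbers.

On these data alone, whether an amine, a carboxylic acid or a longer chain such as butoxy in this same place would give a number beyond the scatter remains open. So does whether bromine or a methyl group in place of the chlorine would do so, since only hydrogen, methoxy and chloro appear among these compounds.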